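Extending the methyl group of compound 3

The source may report more compounds than this note shows. Statements on the series, on what has been measured and on what is new or still open speak of the compounds shown alone.

In an ADME assay on BaF3 cells (Mus musculus) for antiproliferative activity, read by CCK-8 assay, with a stated time of 72 h (on this read-out lower numbers stand for stronger inhibition of growth and higher numbers for weaker inhibition of growth), compound 1 `O=C(CCSc1ccc2c(/C=C/c3ccccn3)n[nH]c2c1)Nc1cccc(F)c1` gives 6590 nM. Compound 2 `Cc1ccc(NC(=O)CCSc2ccc3c(/C=C/c4ccccn4)n[nH]c3c2)cc1` reads > 10000 nM, which is a limit of the assay. Going by the values given here, compound 3 `Cc1ccc(NC(=O)CCSc2ccc3c(/C=C/c4ccccn4)n[nH]c3c2)cc1C(F)(F)F` gives 530 nM, the lowest number so far, and it stands clear of both others: a 12-fold lower number from compound 1 to compound 3 (1.09 log units; beyond the scatter) and an at least 18-fold lower number from compound 2 to compound 3 (1.27 log units; beyond the scatter).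

Compound 4 `O=C(CCSc1ccc2c(/C=C/c3ccccn3)n[nH]c2c1)Nc1ccc(CN2CCCC2)c(C(F)(F)F)c1` keeps the trifluoromethyl group of compound 3 and carries pyrrolidin-1-yl in place of hydrogen on a saturated chain carbon bound to an aromatic carbon, so that methyl becomes (pyrrolidin-1-yl)methyl.

Among the compounds with values here, no measured step changes that carbon. The nearest evidence is the large step that added trifluoromethyl to compound 2, an at least 18-fold lower number from compound 2 to compound 3 (1.27 log units; beyond the scatter), which shows that the number can move strongly with a small change on this same aromatic ring. A moderate change towards a lower number is therefore expected, with wide uncertainty. The estimated step is a 2.7-fold lower number from compound 3 to compound 4 (0.42 log units; beyond the scatter). For compound 4 the expected value is 200 nM, with an estimated range of 40 nM to 1000 nM.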

Compound 4, concentration for 50% growth inhibition: 4000 nM
Beside the measured number, compound 4's estimate is 20-fold (1.30 log units) below it; the whole stated range lies below it.
By their numbers in this assay, from the lowest: compound 3; then compounds 4 and 1 (each within the scatter of the next). At a limit, above all of these: compound 2.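

In this assay the change from methyl to (pyrrolidin-1-yl)methyl gives a 7.5-fold higher number from compound 3 to compound 4 (0.88 log units; beyond the scatter) and so weaker inhibition of growth, a modest loss with the trifluoromethyl group kept in place. Going by these compounds alone, the earlier steps changed only groups on the aromatic ring, so this is the first sign that the number also responds to what is carried on the saturated chain carbon bound to that ring. Nothing given here accounts for the size or direction of this step.

Whether the loss belongs to the pyrrolidine ring itself or to any larger group on this carbon stays open, as only one such group is shown. An open-chain amine such as dimethylamino, a morpholine ring or a plain ethyl chain at this place would help to separate the two.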